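Pyrrolyl for Phenyl on a Benzimidazole Proline Amide Core

A few compounds are considered here, and "the series" means these few. Any claim that something is new, unique, unknown or untested is made for them only; others in the source may bear on it.

Of the compounds shown here, three have been measured in an assay on CHO cells for displacement of a labelled ligand from Orexin receptor type 2 (Homo sapiens); a lower number here means a stronger inhibitor, a higher number a weaker inhibitor. Compound 1 `Cn1c(SCC(=O)N2CCC[C@H]2C(=O)Nc2ccccc2-n2cccc2)nc2ccccc21` gives 0.3 nM in this assay, and compound 2 `Cn1c(SCC(=O)N2CCC[C@H]2C(=O)Nc2ccccc2-c2ccccc2)nc2ccccc21` gives 0.2 nM. Compound 3 `O=C(Nc1ccccc1-c1ccccc1)[C@@H]1CCCN1C(=O)CCc1nc2ccccc2[nH]1` differs from compound 2 in its core, the difference being ((1H-benzimidazol-2-yl)methyl in place of (1-methyl-1H-benzimidazol-2-yl)sulfanyl on a saturated chain carbon bound to a carbonyl carbon), and in this assay compound 3 gives 6 nM; the step is a 30-fold higher number from compound 2 to compound 3 (1.48 log units; beyond the scatter). Compound 4 `O=C(Nc1ccccc1-n1cccc1)[C@@H]1CCCN1C(=O)CCc1nc2ccccc2[nH]1` has not yet been measured.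

The change from compound 3 to compound 4 is 1H-pyrrol-1-yl in place of phenyl on an aromatic carbon. The same change, with the same surroundings, has already been made once among these compounds, from compound 2 to compound 1, where it is 1H-pyrrol-1-yl in place of phenyl on an aromatic carbon and the step was a 1.5-fold higher number from compound 2 to compound 1 (0.18 log units; within the scatter).

Among the compounds with values here, on that one precedent, the step from compound 3 to compound 4 is expected to be small, about a 1.3-fold higher number from compound 3 to compound 4 (0.12 log units; within the scatter), because the only earlier instance of this change gave a 1.5-fold higher number from compound 2 to compound 1 (0.18 log units; within the scatter). The expectation rests on a single pair, and the core of compound 3 is not that of compound 2, so the spread around the estimate is kept wide. Compound 4 is therefore estimated at 8 nM, between 3 nM and 20 nM.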

Compound 4, inhibition constant: 11 nM
The estimate for compound 4 lay 1.4-fold (0.14 log units) below the measured number; low and high end bracket the measured number.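

In this assay, 1H-pyrrol-1-yl in place of phenyl gives a 1.8-fold higher number from compound 3 to compound 4 (0.26 log units; within the scatter) and behaves alike on the two cores: the same change on two cores in this assay, a 1.5-fold higher number (0.18 log units; within the scatter) from compound 2 to compound 1 and a 1.8-fold higher number (0.26 log units; within the scatter) from compound 3 to compound 4, 1.2-fold (0.09 log units) apart, within the scatter of two such steps. The change of core, read with 1H-pyrrol-1-yl in place, gives a 37-fold higher number from compound 1 to compound 4 (1.56 log units; beyond the scatter) and also matches its earlier counterpart: the same change on two cores in this assay, a 30-fold higher number (1.48 log units; beyond the scatter) from compound 2 to compound 3 and a 37-fold higher number (1.56 log units; beyond the scatter) from compound 1 to compound 4, 1.2-fold (0.09 log units) apart, within the scatter of two such steps. Within the data shown here, in this series the two changes therefore carry over with no sign that one depends on the other, but this rests on only two pairs among four compounds, and it shows nothing about other cores or about other groups on that aromatic carbon.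

The compounds shown leave open which part of the change from (1-methyl-1H-benzimidazol-2-yl)sulfanyl to (1H-benzimidazol-2-yl)methyl carries the large step, the sulfur or the methyl, since the two always change together here. From the compounds shown here alone, it also remains open whether a pyridyl ring or a small group such as methyl or chlorine on that aromatic carbon would fit the same pattern.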